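A few compounds are considered here, and "the series" means these few. Any claim that something is new, unique, unknown or untested is made for them only; others in the source may bear on it.

Measured so far:
compound 1, `COc1cc(/C=C/C(=O)Nc2ccccc2)ccc1OCCCN(C)C`, 1.55
compound 2, `COc1cc(/C=C/C(=O)Nc2ccccc2)ccc1OCCCCCN1CCCCC1`, 1.65
compound 3, `COc1cc(/C=C/C(=O)Nc2ccccc2)ccc1OCCCCCCCCN(C)C`, 1.74

In a physicochemical assay for lipophilicity, using the shake flask method, measured as octanol-water partition, at pH 7.4 (a higher number here means a more lipophilic compound, a lower number a more polar compound), compound 1 holds the lowest of the three numbers, though its nearest neighbour is compound 2 at a number 0.10 log units higher from compound 1 to compound 2 (within the scatter) and its furthest is compound 3 at a number 0.19 log units higher from compound 1 to compound 3 (within the scatter); neither gap is beyond the scatter, so the three stand level. The step from compound 2 to compound 3, a number 0.09 log units higher from compound 2 to compound 3 (within the scatter), is likewise within the scatter.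

Compound 4, `CCN(CC)CCCCCCCCOc1ccc(/C=C/C(=O)Nc2ccccc2)cc1OC`, has not yet been measured in this assay. It differs from compound 1 as follows: 5-(diethylamino)pentyl in place of dimethylamino on a saturated chain carbon, three bonds along the chain from an oxygen on an aromatic ring. Among the compounds with values here, the closest precedent is the step from compound 1 to compound 3, where a 5-(dimethylamino)pentyl replaced the dimethylamino and gave a number 0.19 log units higher from compound 1 to compound 3 (within the scatter). Compound 4 carries the same pentyl extension, with a diethylamino in place of the dimethylamino at its end, which adds a little more again. On these grounds the step is expected to be modest and upward: a number 0.35 log units higher from compound 1 to compound 4 (beyond the scatter). Compound 4 is therefore estimated to give 1.9 in this assay, within a range of 1.5 to 2.4.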

Compound 4, partition coefficient: 1.75
Compound 4: the middle estimate sits 0.15 log units above what was measured; measured number inside the range.
By their numbers in this assay, from the lowest: compounds 1, 2, 3 and 4 (each within the scatter of the next).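

At this place, on a saturated chain carbon three bonds along the chain from an oxygen on an aromatic ring, 5-(diethylamino)pentyl in place of dimethylamino gives a step in this assay (a number 0.20 log units higher from compound 1 to compound 4 (within the scatter)) that stays within the scatter, as does the change from dimethylamino to diethylamino at the far end of the long chain (a number 0.01 log units higher from compound 3 to compound 4 (within the scatter)) and 3-(diethylamino)propyl in place of piperidin-1-yl (a number 0.10 log units higher from compound 2 to compound 4 (within the scatter)). Compound 4 therefore stands level with compounds 1, 2 and 3, so the four amine-ended chains shown cannot be told apart in this assay, even with the largest group yet at this place. Nothing shown accounts for this.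

The compounds leave open whether a different end group on the chain, such as a carboxylic acid or a morpholine, would give a step beyond the scatter. They also leave open whether a chain ending in a hydroxyl group, with no amine, would do so.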